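The compounds below may be only part of what the source reports. "The series", "measured", "known", "first", "only" and "open" are said of these compounds alone.

Series notes. Compound 1 `Cc1cc(COc2cc(F)c(F)c(F)c2)nc(-c2ccccn2)n1` in a functional assay on cells for antagonist activity at Free fatty acid receptor 1 (Homo sapiens), read by TR-FRET and inositol phosphate accumulation, with a stated time of 2 h (a higher number here means a weaker inhibitor, a lower number a stronger inhibitor), gives 398 nM. Compound 2 `CC1(C)CN(c2cc(COc3ccc(F)c(F)c3F)nc(-c3ccccn3)n2)C1` in this assay gives 25.1 nM, the lowest of the two numbers in hand; the gap to compound 1 is beyond the scatter. Compound 3 `CC1(CS(C)(=O)=O)CN(c2cc(COc3ccc(F)c(F)c3F)nc(-c3ccccn3)n2)C1` differs from compound 2 by methylsulfonyl in place of hydrogen on a saturated chain carbon bound to a saturated ring carbon. Within the data shown here, no measured pair shows this change, so its effect is unknown; a step from compound 2 to compound 3 of a 1.6-fold higher number from compound 2 to compound 3 (0.20 log units; within the scatter) toward a slightly weaker number is expected, close to the scatter. Compound 3 is expected at 40 nM, with a range from 10 nM to 160 nM.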

Compound 3, half-maximal inhibitory concentration: 6310 nM
Compound 3: middle estimate off by 160-fold (2.20 log units), on the low side; measured number outside the range, above it.
By their numbers in this assay, from the lowest: compound 2; then compound 1; then compound 3.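

In this assay, methylsulfonyl in place of hydrogen on a saturated chain carbon bound to a saturated ring carbon brings a 250-fold higher number from compound 2 to compound 3 (2.40 log units; beyond the scatter) and thus a large loss of inhibition. The earlier compounds shown here held no change at this carbon, which now proves sensitive, at least to this group. Nothing in hand accounts for the size of the step.

On these data alone, whether the loss is specific to methylsulfonyl remains open. A hydroxyl, a nitrile, a carboxylic acid or an amine at the same carbon would test how far it extends.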